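The source may hold more compounds than are shown below. What is called first, only, known or untested is meant among the compounds shown, and "the series" means these compounds.

Values so far in a functional assay on HepG2 cells (Homo sapiens) for antiproliferative activity, read by MTT assay, with a stated time of 48 h; on this read-out higher numbers stand for weaker inhibition and lower numbers for stronger inhibition:

- Compound 1 `CCCC(C)Oc1ccc(C(=O)/C=C/c2c(/C=C/c3ccc(OC)cc3)cc(OC)cc2OC)cc1` gives 11.1 ug/mL
- Compound 2 `COc1ccc(/C=C/c2cc(OC)cc(OC)c2/C=C/C(=O)c2ccc(C)cc2)cc1` gives 4.8 ug/mL
- Compound 3 `CCCCOc1ccc(C(=O)/C=C/c2c(/C=C/c3ccc(OC)cc3)cc(OC)cc2OC)cc1` gives 12.9 ug/mL

Compound 3 stands at the upper end of these numbers. The series shows a 1.2-fold higher number from compound 1 to compound 3 (0.07 log units; within the scatter), and also a 2.7-fold higher number from compound 2 to compound 3 (0.43 log units; beyond the scatter), so only compound 2 lies clearly apart from it.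

The next compound is compound 4 `COc1ccc(/C=C/c2cc(OC)cc(OC)c2/C=C/C(=O)c2cccc(Br)c2)cc1`, which is still unmeasured. The change is 3-bromophenyl in place of 4-butoxyphenyl on a carbonyl carbon. For the measured compounds named here, no measured compound carries the 3-bromophenyl group, so the evidence is indirect. The nearest guide is compound 2, which also lacks the butoxy chain and gives 4.8 ug/mL in this assay. Two modest steps link compound 2 to the compounds with longer chains. One is a 2.3-fold lower number from compound 1 to compound 2 (0.36 log units; beyond the scatter), and the other is a 2.7-fold higher number from compound 2 to compound 3 (0.43 log units; beyond the scatter), which read in reverse points the same way. The data do not show whether compound 4 will follow compound 2, so the range stays wide.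

A modest step toward lower numbers is expected, an estimated 2.2-fold lower number from compound 3 to compound 4 (0.33 log units; beyond the scatter) here. Compound 4 is therefore expected at 6 ug/mL, with an estimated range from 2.5 ug/mL to 14 ug/mL.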

Compound 4, half-maximal inhibitory concentration: 13 ug/mL
The estimate for compound 4 lay 2.2-fold (0.34 log units) below the measured number, and the stated range covers the measured number.
By their numbers in this assay, from the lowest: compound 2; then compounds 1, 3 and 4 (each within the scatter of the next).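

In this assay, 3-bromophenyl in place of 4-butoxyphenyl on the carbonyl carbon leaves the number unchanged (a 1.0-fold higher number from compound 3 to compound 4 (0.00 log units; within the scatter)), and the comparison with the 4-(1-methylbutoxy)phenyl group reads the same way (a 1.2-fold higher number from compound 1 to compound 4 (0.07 log units; within the scatter)). The earlier compounds left open whether dropping the oxygen-linked chain was enough to reach the lower number of the 4-methylphenyl compound, but the 3-bromophenyl group also lacks such a chain and still stands apart from 4-methylphenyl by a modest step (a 2.7-fold higher number from compound 2 to compound 4 (0.43 log units; beyond the scatter)), so among these four compounds, the absence of the chain does not by itself go with a lower number, and compound 4 is the one that goes against that reading. Nothing available here accounts for the gap between the 3-bromophenyl and 4-methylphenyl groups.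

The step between these two groups changes both the substituent and its place on the ring, so the compounds shown cannot separate the two changes. They also leave open how a chlorine, a methoxy group or an amine on this ring would read in this assay.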